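Cytotoxicity notes on three measured analogues and one candidate

The source may hold more compounds than are shown below. What is called first, only, known or untested is meant among the compounds shown, and "the series" means these compounds.

Measured compounds:
- compound 1, `Cc1cn([C@@H]2O[C@H](CO[Si](C)(C)C(C)(C)C)[C@@]3(OS(=O)(=O)C=C3NCC(=O)C(=O)N3CCC3)[C@H]2O[Si](C)(C)C(C)(C)C)c(=O)n(C)c1=O` — 65000 nM
- compound 2, `CCOC(=O)NC(=O)NC1=CS(=O)(=O)O[C@@]12[C@@H](CO[Si](C)(C)C(C)(C)C)O[C@@H](n1cc(C)c(=O)n(C)c1=O)[C@@H]2O[Si](C)(C)C(C)(C)C` — 16000 nM
- compound 3, `COC(=O)NC1=CS(=O)(=O)O[C@@]12[C@@H](CO[Si](C)(C)C(C)(C)C)O[C@@H](n1cc(C)c(=O)n(C)c1=O)[C@@H]2O[Si](C)(C)C(C)(C)C` — >= 50000 nM

In a functional assay on HEL cells (Homo sapiens) for cytotoxicity, read by microscopy (a lower number here means that less compound is tolerated, a higher number that more compound is tolerated), compound 1 gives 65000 nM, and compound 2 gives 16000 nM. For compound 3 the assay reports only a limit, >= 50000 nM. Within the data shown here, compound 3 therefore stands at the upper edge of what has been observed in this set, and the read-out is a limit rather than a number; the one step in which it is the endpoint reads as an at least 3.1-fold higher number from compound 2 to compound 3 (0.49 log units; beyond the scatter). The two steps from compound 1 are a 4.1-fold lower number from compound 1 to compound 2 (0.61 log units; beyond the scatter) and a step that the limit leaves unreadable from compound 1 to compound 3.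

Compound 4, `COC(=O)CC(=O)NC1=CS(=O)(=O)O[C@@]12[C@@H](CO[Si](C)(C)C(C)(C)C)O[C@@H](n1cc(C)c(=O)n(C)c1=O)[C@@H]2O[Si](C)(C)C(C)(C)C`, differs from compound 3 only at the carbonyl carbon whose other neighbour is the amide-type nitrogen: (methoxycarbonyl)methyl in place of methoxy on a carbonyl carbon. Among the measured compounds shown here, the only measured step at this carbon is an at least 3.1-fold higher number from compound 2 to compound 3 (0.49 log units; beyond the scatter), in which a larger substituent on the same carbon went with a lower number, beyond the scatter. Putting a (methoxycarbonyl)methyl group in place of methoxy again enlarges that substituent, so a modest step downward is expected, with compound 2 as the nearest guide. For compound 4 the expected step is an at least 1.6-fold lower number from compound 3 to compound 4 (0.22 log units; that floor lies within the scatter), giving an estimate of 30000 nM with a range of 10000 nM to 80000 nM; a reading that again ends at the limit of >= 50000 nM in this assay, at which 1 of the 3 values shown sits, remains plausible.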

Compound 4, minimum cytotoxic concentration: 400000 nM
Compound 4: middle estimate off by 13-fold (1.12 log units), on the low side, and the stated range ends below it.
By their numbers in this assay, from the lowest: compound 2; then compound 1; then compound 4.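

In this assay the carbonyl carbon whose other neighbour is the amide-type nitrogen tolerates a larger substituent without the number falling, and compound 4 goes against the link between size and a lower number that compound 2 had suggested. Replacing (ethoxycarbonyl)amino with (methoxycarbonyl)methyl on this carbon gives a 25-fold higher number from compound 2 to compound 4 (1.40 log units; beyond the scatter) and is the largest readable step in the set, so the size of the substituent alone does not set the number here. Compound 4 also stands clear of the compound with the (((azetidin-1-yl)carbonyl)carbonyl)methyl group on the amine nitrogen, with a 6.2-fold higher number from compound 1 to compound 4 (0.79 log units; beyond the scatter) for the change to ((methoxycarbonyl)methyl)carbonyl.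

Going by these compounds, compound 3 carries only a limit, so the step from compound 3 to compound 4 cannot be read, and how far (methoxycarbonyl)methyl moves the number relative to methoxy stays open: the limit of >= 50000 nM in this assay, at which 1 of the 4 values shown sits. Nor do these compounds separate the contribution of the methyl ester from that of the carbon link to the carbonyl, which a carboxylic acid or a longer chain at this carbonyl carbon would address.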